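From benzyl to 4-propylphenyl on the shared core

The compounds below may be only part of what the source reports. "The series", "measured", "known", "first", "only" and "open" are said of these compounds alone.

Measured in a functional assay on MCF7 cells (Homo sapiens) for inhibition, read by sulforhodamine B assay; a higher number here means a weaker inhibitor, a lower number a stronger inhibitor:
compound 1 `O=C1C(Nc2ccc(C(F)(F)F)cc2)=CC(=O)c2c1nc1n2[C@H]2OC[C@@H](O)[C@H]2OC1`: > 4000 nM (a limit)
compound 2 `COc1ccc(NC2=CC(=O)c3c(nc4n3[C@H]3OC[C@@H](O)[C@H]3OC4)C2=O)cc1`: 4470 nM
compound 3 `O=C1C(NCc2ccccc2)=CC(=O)c2c1nc1n2[C@H]2OC[C@@H](O)[C@H]2OC1`: > 8000 nM (a limit)

Compound 3 stands only at a limit, > 8000 nM, so no number is known for it. Compound 1 also gives only a limit, > 4000 nM.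

Compound 4 `CCCc1ccc(NC2=CC(=O)c3c(nc4n3[C@H]3OC[C@@H](O)[C@H]3OC4)C2=O)cc1` differs from compound 3 by 4-propylphenyl in place of benzyl on an amine nitrogen. The closest measured change is an at least 1.7-fold higher number from compound 2 to compound 3 (0.25 log units; that floor lies within the scatter), with benzyl entering rather than leaving. The other two steps give no size: a step that the limit leaves unreadable from compound 1 to compound 2, and a step that the two limits leave unreadable from compound 1 to compound 3.

Compound 4 has a substituted phenyl on that nitrogen, as compound 2 does, so a value near the 4470 nM of compound 2 is expected. A modest fall in the number is therefore expected in this assay, though it may stay within the scatter. The expected change is an at least 1.7-fold lower number from compound 3 to compound 4 (0.24 log units; that floor lies within the scatter). For compound 4 the estimate is 4500 nM, with an expected range of 1800 nM to 11000 nM.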

Compound 4, half-maximal inhibitory concentration: > 4000 nM
Compound 4: a limit, no number; the forecaster's own chance of this, stated with the estimate: 35%; the middle value lies beyond the limit too.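

In this assay, among the compounds shown here, compound 4 gives only a limit, > 4000 nM, so no step from compound 1, compound 2 or compound 3 to compound 4 can be read. The compounds shown leave open what number compound 4 would reach and how 4-propylphenyl truly compares with benzyl on that amine nitrogen.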